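A few compounds are considered here, and "the series" means these few. Any claim that something is new, unique, unknown or untested is made for them only; others in the source may bear on it.

Of the compounds shown here, three of one series have been tested in a functional assay on the whole organism (artery, strain albino) with Rattus norvegicus as the target, with a stated time of 120 min, at a dose of 10 mg/kg by the oral route (on this read-out lower numbers stand for less inhibition and higher numbers for more inhibition at the one dose given (going by the name of the read-out)), and a fourth awaits its turn. Compound 1, `COc1ccc(C2N=C(SCc3ccc(Cl)cc3)NC(C)=C2C(=O)Nc2ccc(F)cc2)cc1OC`, gives 15.5% in this assay. Compound 2, `COc1ccc(C2N=C(SCc3ccc(F)cc3)NC(C)=C2C(=O)Nc2ccc(F)cc2)cc1OC`, differs from it by fluoro in place of chloro on an aromatic carbon and gives 15.5% in this assay. This single change produced no change at the digits printed from compound 1 to compound 2 (within the scatter) in this assay, so the two values show no separation that the method could resolve.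

Compound 3, `CC1=C(C(=O)Nc2ccc(Br)cc2)C(c2ccc(Cl)cc2Cl)N=C(SCc2ccc(Cl)cc2)N1`, carries a different core; how that core differs from the core of compound 1 is not broken down here. In this assay compound 3 gives 17.5%, a value that sits close to those of compound 1 and of compound 2, with none of the three set apart from the others.

Compound 4, `CC1=C(C(=O)Nc2ccc(Br)cc2)C(c2ccc(Cl)cc2Cl)N=C(SCc2ccc(F)cc2)N1`, has not yet been measured in this assay. It differs from compound 3 by fluoro in place of chloro on an aromatic carbon, the same change that turns compound 1 into compound 2, and at the same kind of place as described for both pairs. For compound 4 the expected step from compound 3 is a number 0.5 percentage points lower from compound 3 to compound 4 (within the scatter) in this assay, an expectation that rests on the earlier step of no change at the digits printed from compound 1 to compound 2 (within the scatter) made by the same change. Compound 4 is therefore estimated to give 17% in this assay, with the likely range running from 7% to 27%.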

Compound 4, a percentage reported as inhibition, in the whole organism at one dose (the size of the read-out at that dose, not a potency): 22.7%
Compound 4: the middle estimate sits 5.7 percentage points below what was measured; measured number inside the range.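

In this assay, putting fluoro in place of chloro on the core of compound 3 gives a number 5.2 percentage points higher from compound 3 to compound 4 (within the scatter), and set beside the same change on the core of compound 1, the two steps do not come apart: the same change on two cores in this assay, no change at the digits printed (within the scatter) from compound 1 to compound 2 and a number 5.2 percentage points higher (within the scatter) from compound 3 to compound 4, 5.2 percentage points apart, within the scatter of two such steps As far as these two pairs go, the exchange of 4-chlorobenzyl for 4-fluorobenzyl therefore reads the same on both cores, and neither step can be told from repeated measurement of a single compound. This does not show that the change carries a shared effect from one core to the other, since neither step is resolved from no change at all, so the agreement between them is only an agreement of two small differences, each measured at one oral dose and with no potency behind it.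

The compounds shown leave open whether anything on this benzyl group would move the read-out beyond the scatter, as all four carry only chloro or fluoro there, so a methoxy group, an amine or a carboxylic acid in that place remains untested here. Also open, going by these compounds, is whether a longer chain between the sulfur and the aromatic ring would change the picture on either core.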